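This account rests on a few compounds, and the source may have more. Where it says the series, first, only, none or still open, it means among the compounds named here.

Measured compounds and their numbers in a functional assay on MCF7 cells (Homo sapiens) for antiproliferative activity, tested at 1 uM; on this read-out lower numbers stand for less inhibition and higher numbers for more inhibition at the one concentration tested (going by the name of the read-out):

compound 1 `Cc1c(CO/N=C/c2c(-c3ccccc3)nn(-c3ccccc3)c2Oc2ccc(Cl)cc2)cccc1-c1ccccc1`, compound 1 gives -17.5%
compound 2 `Cc1nn(-c2ccccc2)c(Oc2ccc(Cl)cc2)c1/C=N/OCc1ccc(C(=O)OC(C)(C)C)cc1`, compound 2 gives -8.4%
compound 3 `Cc1nn(C)c(Oc2ccc(Cl)cc2)c1/C=N/OCc1ccc(C(F)(F)F)cc1`, compound 3 gives 16.4%

Compound 2 sits close to compound 1 in this assay; the gap between the two is within the scatter, so nothing can be said about which of them inhibits more. Compound 3 lies apart from both: its number in this assay is higher than that of compound 2 by a gap beyond the scatter. Going by the values given here, compound 3 also differs from the others in several places at once, so no single step between measured compounds can be read off, and no step is given.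

Compound 4 `CCOC(=O)c1ccc(CO/N=C/c2c(C)nn(-c3ccccc3)c2Oc2ccc(Cl)cc2)cc1` is the untested member. Relative to compound 2 the change is ethyl in place of tert-butyl on an oxygen next to a carbonyl group. Among the compounds with values here, no measured pair shows what such a change does here, so the expectation rests on compound 2 alone. The step from compound 2 to compound 4 is expected to be small, in no fixed direction, and to stay within the scatter, that is a number 3.4 percentage points higher from compound 2 to compound 4 (within the scatter) in this assay. Compound 4 is therefore estimated at -5%, with a range from -22% to 12%.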

Compound 4, a percentage reported as inhibition, at one concentration (the size of the read-out at that concentration, not a potency): 12%
Estimate against measurement, compound 4: 17 percentage points below; the measured number falls inside the stated range.
By their numbers in this assay, from the lowest: compounds 1 and 2 (each within the scatter of the next); then compounds 4 and 3 (each within the scatter of the next).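

In this assay, the alkyl group on an oxygen next to a carbonyl group is not a silent place in this series: ethyl in place of tert-butyl gives a number 20.4 percentage points higher from compound 2 to compound 4 (beyond the scatter). Going by these compounds alone, this is the first change that can be read in one place, since the earlier compounds differed from one another in several places at once and showed nothing about this position on its own. The step gives the direction and size of the tert-butoxycarbonyl to ethoxycarbonyl change on this one background, but no measurement at hand bears on what lies behind it.

Within the data shown here, with only two groups at this place, it remains open whether the number follows the size of the alkyl group or is specific to the loss of tert-butyl; methyl, a longer chain such as n-butyl, or the free carboxylic acid in the same place would help to settle this. On these data alone, it also remains open whether the same change would give a similar step on a background like that of compound 1 or compound 3, and whether it would hold at concentrations other than the single one tested.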